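This account rests on a few compounds, and the source may have more. Where it says the series, first, only, none or still open, it means among the compounds named here.

Measured compounds:
compound 1 `Oc1c(-c2ccccc2)c(-c2ccccc2)nn1-c1nc2cc(Cl)ccc2[nH]1` — 2000 nM
compound 2 `Cc1[nH]n(-c2nc3cc(Cl)ccc3[nH]2)c(=O)c1Cc1ccccc1` — 4500 nM
compound 3 `Cc1ccc2[nH]c(-n3[nH]c(C)c(Cc4ccccc4)c3=O)nc2c1` — 670 nM

In an assay on isolated protein for inhibition of alpha-ketoglutarate-dependent dioxygenase alkB homolog 3 (Homo sapiens), read by polymerase chain reaction, with a stated time of 1 h (a lower number here means a stronger inhibitor, a higher number a weaker inhibitor), compound 1 gives 2000 nM and compound 2 gives 4500 nM; the gap between these two lies beyond the scatter. The difference between the two cores is not broken down here. Within the core of compound 2, one change is measured: methyl in place of chloro on an aromatic carbon, giving a 6.7-fold lower number from compound 2 to compound 3 (0.83 log units; beyond the scatter) in this assay, so compound 3 comes in at 670 nM.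

Compound 4 `Cc1ccc2[nH]c(-n3nc(-c4ccccc4)c(-c4ccccc4)c3O)nc2c1` is not yet measured. It carries the same change on the core of compound 1: methyl in place of chloro on an aromatic carbon. The place is the same in both pairs. Going by the values given here, compound 4 is expected to follow the step from compound 2 to compound 3, damped somewhat as only one example exists, giving an estimated 4.0-fold lower number from compound 1 to compound 4 (0.60 log units; beyond the scatter). Compound 4 is therefore estimated at 500 nM, expected between 150 nM and 1500 nM.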

Compound 4, half-maximal inhibitory concentration: 5800 nM
Beside the measured number, compound 4's estimate is 12-fold (1.06 log units) below it; the measured number lies above the stated range.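

In this assay, methyl in place of chloro on an aromatic carbon gives a 2.9-fold higher number from compound 1 to compound 4 (0.46 log units; beyond the scatter), which runs opposite to the step on the core of compound 2, and the two steps differ: the same change on two cores in this assay, a 6.7-fold lower number (0.83 log units; beyond the scatter) from compound 2 to compound 3 and a 2.9-fold higher number (0.46 log units; beyond the scatter) from compound 1 to compound 4, 19-fold (1.29 log units) apart, beyond the scatter of two such steps. For these two pairs, the change does not carry from one core to the other, in size or in direction. Two pairs do not show why the steps part, nor how the change behaves on any further core.

Still open, going by these compounds, is how a group other than chloro or methyl in this place, such as methoxy, an amine or a carboxylic acid, reads on either core. Also open, on these data alone, is which difference between the two cores, such as the two phenyl groups of compound 1 against the benzyl and methyl groups of compound 2, sets the direction of the step.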